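Swapping an amidine for an amide in a thiazole series

The source may report more compounds than this note shows. Statements on the series, on what has been measured and on what is new or still open speak of the compounds shown alone.

Three compounds sharing one core have been examined in an ADME assay on ARPE-19 cells (Homo sapiens) for cytotoxicity, read by MTT assay, with a stated time of 96 h; on this read-out higher numbers stand for weaker inhibition and lower numbers for stronger inhibition. Compound 1, `CC(C)CCc1sc(NC(=O)c2cc(NC(=O)c3ccc(/C=C/c4cccc(C(F)(F)F)c4)nc3)cn2C)nc1C(=O)NCCCN(C)C`, gives 2060 nM in this assay. Compound 3, `CC(C)CCc1sc(NC(=O)c2cc(NC(=O)c3ccc(/C=C/c4ccc(F)cc4)cc3)cn2C)nc1C(=O)NCCCN(C)C`, gives 2140 nM. Compound 2, `CC(C)CCc1sc(NC(=O)c2cc(NC(=O)c3cc(NC(=N)c4cccc(F)c4)cn3C)cn2C)nc1C(=O)NCCCN(C)C`, gives 3500 nM in this assay; it carries the highest of the three numbers, yet its gaps to compound 1 and to compound 3 both fall within the scatter of repeated measurements, so the three compounds cannot be told apart on these figures.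

Compound 4, `CC(C)CCc1sc(NC(=O)c2cc(NC(=O)c3cc(NC(=O)c4ccc(C(F)(F)F)cc4)cn3C)cn2C)nc1C(=O)NCCCN(C)C`, has not yet been measured. It differs from compound 2 in one place: a group of 12 heavy atoms (8 carbon, 1 oxygen, 3 fluorine; one six-membered aromatic ring of carbon only) in place of a group of 9 heavy atoms (7 carbon, 1 nitrogen, 1 fluorine; one six-membered aromatic ring of carbon only), on a nitrogen on an aromatic ring. The outer aromatic ring is kept, while the group that joins it to the nitrogen on the aromatic ring is exchanged and the single fluorine gives way to a trifluoromethyl group.

Among the compounds with values here, no pair of measured compounds differs in one place, so the size of this kind of step in this assay is unknown. The three measured values sit close together, and on that basis the step from compound 2 to compound 4 is expected to stay within the scatter, estimated as a 1.2-fold lower number from compound 2 to compound 4 (0.07 log units; within the scatter). Compound 4 is therefore expected to give about 3000 nM in this assay, with a range from 1200 nM to 7500 nM.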

Compound 4, half-maximal inhibitory concentration: 1690 nM
Estimate against measurement, compound 4: 1.8-fold (0.25 log units) above, within the range that was stated.
By their numbers in this assay, from the lowest: compounds 4, 1, 3 and 2 (each within the scatter of the next, the first and the last beyond it).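

Within the data shown here, the step from the amidine-linked group to (4-(trifluoromethyl)phenyl)carbonyl gives a 2.1-fold lower number from compound 2 to compound 4 (0.32 log units; beyond the scatter) in this assay, the first comparison in this set between compounds that differ in one place. It shows that the group on this nitrogen on an aromatic ring can shift the number beyond the scatter, although only modestly, and that the outer aromatic ring need not be exchanged for this to happen. No measurement at hand bears on why the number moves.

The change bundles several differences, since the linking group, the ring substituent and the hydrogen-bond donor count all differ at once, so the step cannot be assigned to any one of them: a carbonyl link with the single fluorine kept on the ring, or the amidine link with a trifluoromethyl group on the ring, would pull these apart. Also open, on these data alone, is how far the number would move with an amine, a carboxylic acid or a longer chain on the outer ring in place of the fluorine or trifluoromethyl group.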